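The source may report more compounds than this note shows. Statements on the series, on what has been measured and on what is new or still open speak of the compounds shown alone.

In a functional assay on MCF7 cells (Homo sapiens) for antiproliferative activity, read by MTT assay, with a stated time of 48 h (on this read-out lower numbers stand for stronger inhibition and higher numbers for weaker inhibition), compound 1 (`COc1ccc(/C=C/C=C\c2cc(OC)c(OC)c(OC)c2)cc1O`) gives 75 nM as its value and compound 2 (`CCOc1cc(-c2ccc3cc[nH]c3c2)cn2c(-c3cc(OC)c(OC)c(OC)c3)nnc12`) gives 334 nM on the same read-out. Compound 3 (`COc1cc(-c2nnc3c(OC4COC4)cc(-c4ccc5[nH]ccc5c4)cn23)cc(OC)c1OC`) gives 2470 nM and so stands highest of the three, the weakest inhibitor here, beyond the scatter from both others. Compound 4 (`COc1cc(-c2nnc3c(OC4CN(C(C)(C)C)C4)cc(-c4ccc5[nH]ccc5c4)cn23)cc(OC)c1OC`) is otherwise compound 3 but has 1-(tert-butyl)azetidin-3-yl in place of oxetan-3-yl on an oxygen on an aromatic ring. For the measured compounds named here, no measured pair isolates this change, so the expectation starts from compound 3 at 2470 nM alone. The estimated step (a 1.6-fold lower number from compound 3 to compound 4 (0.22 log units; within the scatter)) in this assay is expected to be small, toward stronger inhibition, and within the scatter. For compound 4 the expected value is 1500 nM with 400 nM to 6000 nM as the estimated range.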

Compound 4, half-maximal inhibitory concentration: > 10000 nM
Compound 4: only a limit was reported; the forecaster's own chance of this, stated with the estimate: 5%; at least 6.6-fold (0.82 log units) between middle value and limit.
By their numbers in this assay, from the lowest: compound 1; then compound 2; then compound 3. At a limit, above all of these: compound 4.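

On an oxygen on an aromatic ring, 1-(tert-butyl)azetidin-3-yl in place of oxetan-3-yl gives an at least 4.0-fold higher number from compound 3 to compound 4 (0.60 log units; beyond the scatter) in this assay. This position therefore responds to the group it carries, and this change moves toward weaker inhibition. Compound 4 is reported only as a limit, so the full size of the step stays unfixed: the limit of > 10000 nM in this assay, at which 1 of the 4 values shown sits.

The ring atom and the tert-butyl group change together here, and the shown compounds do not separate them. An azetidin-3-yl with a free ring amine on this oxygen would separate the two.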